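A Third Methoxy Group on a Cytotoxicity-Silent Scaffold

A few compounds are considered here, and "the series" means these few. Any claim that something is new, unique, unknown or untested is made for them only; others in the source may bear on it.

Compound 2 `COc1ccc(/C(Cl)=C/C=C(\C#N)C(=O)c2c(C)[nH]c3ccccc23)cc1OC` was examined in a functional assay on MCF7 cells (Homo sapiens) for cytotoxicity, read by sulforhodamine B assay, with a stated time of 48 h; on this read-out lower numbers stand for higher toxicity in this test and higher numbers for lower toxicity in this test. Compound 2 gives only a limit there, > 100000 nM, and not a measured number. A related compound 1 `COc1cc(/C(Cl)=C/C=C(\C#N)C(=O)c2c[nH]c3ccc(Br)cc23)cc(OC)c1OC` shares the chlorovinyl and nitrile-bearing chain but differs in several places at once. Compound 1 likewise returns only a limit, > 100000 nM, in this assay. Both values sit at the limit of > 100000 nM in this assay, at which 2 of the 2 values shown sit, so neither compound shows measurable cytotoxicity within the tested range. Compound 3 `COc1cc(/C(Cl)=C/C=C(\C#N)C(=O)c2c(C)[nH]c3ccccc23)cc(OC)c1OC` differs from compound 2 in a single place: methoxy in place of hydrogen on an aromatic carbon. No measured step of this kind exists among these compounds, so the size of the change is unknown from the data. Compound 3 is expected to show a step that the limit leaves unreadable from compound 2 to compound 3, with no shift beyond the usual scatter. Compound 3 is therefore estimated at 150000 nM, in a range from 50000 nM to 500000 nM, most likely reported again only as a limit.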

Compound 3, concentration lethal to 50% of the cells: > 100000 nM
Compound 3 was reported as a limit; the forecaster's own chance of this, stated with the estimate: 85%; the middle value is on the limit's open side.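

Going by these compounds alone, no step from compound 1 or compound 2 to compound 3 can be read, since all three compounds return only a limit: the limit of > 100000 nM in this assay, at which 3 of the 3 values shown sit. The compounds shown leave open what true value each compound has and whether the added methoxy changes cytotoxicity at all.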